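The source may report more compounds than this note shows. Statements on the series, on what has been measured and on what is new or still open speak of the compounds shown alone.

Measured in an ADME assay on Jurkat cells (Homo sapiens) for cytotoxicity, read by MTT assay, with a stated time of 72 h; on this read-out higher numbers stand for weaker inhibition and lower numbers for stronger inhibition:
- compound 1 `O=C(O)c1cnc(Oc2ccc3c(c2)B(O)OC3)cn1`: > 100000 nM (a limit)
- compound 2 `CN(C)C(=O)c1cnc(Oc2ccc3c(c2)B(O)OC3)cn1`: > 100000 nM (a limit)
- compound 3 `CCOC(=O)c1cnc(Oc2ccc3c(c2)B(O)OC3)cn1`: 16800 nM

Among the measured compounds shown here, compound 3 is the only compound with a number, and the other two sit at the limit of > 100000 nM in this assay, at which 2 of the 3 values shown sit.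

Compound 4 `CC(C)OC(=O)c1cnc(Oc2ccc3c(c2)B(O)OC3)cn1` differs from compound 3 by methyl in place of hydrogen on a saturated chain carbon bound to an oxygen next to a carbonyl group and a saturated chain carbon, which turns ethoxycarbonyl into isopropoxycarbonyl.

The closest measured steps are an at least 5.9-fold lower number from compound 1 to compound 3 (0.77 log units; beyond the scatter) and an at least 5.9-fold lower number from compound 2 to compound 3 (0.77 log units; beyond the scatter). Both are beyond the scatter, but neither varies the ethyl group itself, so they give only weak guidance here.

A small change in this assay, within the scatter, is expected, estimated as a 1.3-fold lower number from compound 3 to compound 4 (0.11 log units; within the scatter).

For compound 4 the estimated value is 13000 nM, with an expected range from 5000 nM to 35000 nM.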

Compound 4, half-maximal inhibitory concentration: > 100000 nM
Compound 4: a limit, no number (the forecaster's own chance of this, stated with the estimate: 5%); middle value at least 7.6-fold (0.88 log units) away from the limit.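

The step of an at least 5.9-fold higher number from compound 3 to compound 4 (0.77 log units; beyond the scatter) in this assay shows that the ethoxycarbonyl group does not tolerate every small change: one methyl on the saturated chain carbon is enough to move the read-out beyond the scatter. For compound 4 > 100000 nM is a limit and not a number. Among the compounds shown here, compound 3 remains the only compound with a number, and the steps from compound 1 and compound 2 to compound 4 cannot be read: the limit of > 100000 nM in this assay, at which 3 of the 4 values shown sit.

On these data alone, whether the higher number goes with branching or with the added carbon as such stays open; a straight propyl chain in place of ethyl would separate the two. As far as these compounds go, how a methyl ester would read in this assay is also open.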